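The source may hold more compounds than are shown below. What is called first, only, known or untested is meant among the compounds shown, and "the series" means these compounds.

Measured in a functional assay (strain AB) with Danio rerio as the target, read by microscopy, with a stated time of 1 h; a lower number here means that less compound is needed, a higher number that more compound is needed for the effect:
- Compound 1 `NC(=O)c1c(NC(=O)Nc2ccc(Cl)cc2)sc2c1CCCC2`: > 25000 nM, a limit
- Compound 2 `C[N+](C)(C)C1CCc2c(sc(NC(=O)Nc3ccc(Cl)cc3)c2C(N)=O)C1`: 5870 nM
- Compound 3 `CCC(C)(C)C1CCc2c(sc(NC(=O)Nc3ccc(Cl)cc3)c2C(N)=O)C1`: > 25000 nM, a limit

Compound 3 stands at the limit of > 25000 nM in this assay, at which 2 of the 3 values shown sit, so it has no exact number. Compound 4 `C[N+]1(C2CCc3c(sc(NC(=O)Nc4ccc(Cl)cc4)c3C(N)=O)C2)CCC1` has not yet been measured. The change from compound 3 to compound 4 is a group of 5 heavy atoms (4 carbon, 1 nitrogen; one four-membered non-aromatic ring with 1 hetero atom) in place of a group of 5 heavy atoms (5 carbon; no ring), on a saturated ring carbon. The entering group holds a nitrogen, as does the group on compound 2, and it has a net charge of +1. Adding the nitrogen group gave an at least 4.2-fold lower number from compound 1 to compound 2 (0.62 log units; beyond the scatter). Swapping it for the all-carbon 1,1-dimethylpropyl gave an at least 4.2-fold higher number from compound 2 to compound 3 (0.62 log units; beyond the scatter). Among the measured compounds shown here, the only exact number to lean on is compound 2 at 5870 nM. A move to a lower number, of similar size, is therefore expected: an at least 4.1-fold lower number from compound 3 to compound 4 (0.61 log units; beyond the scatter). For compound 4 the expected value is 6000 nM, with an estimated range of 2000 nM to 20000 nM.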

Compound 4, half-maximal effective concentration: 3920 nM
Estimate against measurement, compound 4: 1.5-fold (0.18 log units) above; measured number inside the range.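

In this assay, a second nitrogen group with a net charge of +1 on the saturated ring carbon, this one holding a four-membered ring, also gives a readable value: an at least 6.3-fold lower number from compound 3 to compound 4 (0.80 log units; beyond the scatter) and an at least 6.3-fold lower number from compound 1 to compound 4 (0.80 log units; beyond the scatter). Against the open nitrogen group of compound 2, the ring makes no clear difference: a 1.5-fold lower number from compound 2 to compound 4 (0.18 log units; within the scatter). Compound 1 and compound 3 hold only a limit, so those two steps have no exact size: the limit of > 25000 nM in this assay, at which 2 of the 4 values shown sit.

Both readable compounds carry the nitrogen and the charge together. From the compounds shown here alone, how a dimethylamino group or a pyrrolidinium ring on this carbon would compare remains open.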